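A Ring Amide Swap Explored in a Frizzled-Related Binder

A few compounds are considered here, and "the series" means these few. Any claim that something is new, unique, unknown or untested is made for them only; others in the source may bear on it.

Among the measured compounds shown here, compound 1 `CN(C)c1ccc(C(=O)N2CCC(NS(=O)(=O)c3cc(S(=O)(=O)c4ccccc4)ccc3C(F)(F)F)CC2)cc1` gives 300 nM in an assay on isolated protein for displacement of a labelled ligand from secreted frizzled-related protein 1 (Homo sapiens), read by fluorescence polarization, with a stated time of 30 min (a higher number here means a weaker inhibitor, a lower number a stronger inhibitor), the higher of the two numbers measured so far. Compound 2 `O=C(O)c1ccc(S(=O)(=O)N2CCC(NS(=O)(=O)c3cc(S(=O)(=O)c4ccccc4)ccc3C(F)(F)F)CC2)cc1` gives 20 nM. For the measured compounds named here, the one measured step, a 15-fold lower number from compound 1 to compound 2 (1.18 log units; beyond the scatter), alters the same end of the molecule that is changed next, but with a different group. Compound 3 `O=C(C1CCNCC1)N1CCC(NS(=O)(=O)c2cc(S(=O)(=O)c3ccccc3)ccc2C(F)(F)F)CC1` differs from compound 1 by piperidin-4-yl in place of 4-(dimethylamino)phenyl on a carbonyl carbon. Going by the values given here, no measured step matches this exact change, so the only guide is that this end of the molecule has tolerated a large alteration. Compound 3 is therefore expected to give about 250 nM (range 50 nM to 1200 nM), a step of a 1.2-fold lower number from compound 1 to compound 3 (0.08 log units; within the scatter) that may well stay within the scatter.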

Compound 3, half-maximal inhibitory concentration: 120 nM
The estimate for compound 3 lay 2.1-fold (0.32 log units) above the measured number; the range from low to high includes it.
By their numbers in this assay, from the lowest: compound 2; then compound 3; then compound 1.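

In this assay, the aromatic 4-(dimethylamino)phenyl on the carbonyl carbon proves dispensable: piperidin-4-yl in its place gives a 2.5-fold lower number from compound 1 to compound 3 (0.40 log units; beyond the scatter). This non-aromatic replacement still falls short of the (4-carboxyphenyl)sulfonyl group, with a 6.0-fold higher number from compound 2 to compound 3 (0.78 log units; beyond the scatter). No evidence here explains either step. From the compounds shown here alone, whether the improvement in compound 3 depends on the ring nitrogen of piperidin-4-yl or on the loss of the aromatic ring remains open. An open-chain amine such as aminoethyl on the same carbonyl carbon would bear on that question.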